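This account rests on a few compounds, and the source may have more. Where it says the series, first, only, none or still open, it means among the compounds named here.

Working notes on the series. Going by the values given here, in an ADME assay on L02 cells (Homo sapiens) for cytotoxicity, read by MTT assay, with a stated time of 24 h (on this read-out higher numbers stand for weaker inhibition and lower numbers for stronger inhibition), compound 1 `O=C1/C(=C/c2cccnc2)CN(S(=O)(=O)c2ccc(F)cc2)C/C1=C\c1ccccc1C(F)(F)F` gives 16100 nM and compound 2 `O=C1/C(=C/c2cccnc2)CN(S(=O)(=O)c2ccc(Cl)cc2)C/C1=C\c1ccccc1C(F)(F)F` gives 11900 nM on the same read-out, so compound 2 cannot be separated from the only other measured number. Compound 3 `N#Cc1ccc(S(=O)(=O)N2C/C(=C\c3cccnc3)C(=O)/C(=C/c3ccccc3C(F)(F)F)C2)cc1` differs from compound 2 by cyano in place of chloro on an aromatic carbon in one place: cyano in place of chloro on an aromatic carbon, para to a large group. Among the compounds with values here, one measured step bears on this change, the swap at that same carbon, a 1.4-fold lower number from compound 1 to compound 2 (0.13 log units; within the scatter) which lies within the scatter. On that single step, no change beyond the scatter is expected in this assay and no direction can be argued. Within the data shown here, no measured compound carries cyano yet. The expected size is a 1.1-fold higher number from compound 2 to compound 3 (0.04 log units; within the scatter) and this stays within the scatter. Compound 3 is estimated at 13000 nM with an expected range from 6000 nM to 28000 nM for now.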

Compound 3, half-maximal inhibitory concentration: 13200 nM
Compound 3: the middle estimate sits 1.0-fold (0.01 log units) below what was measured; low and high end bracket the measured number.
By their numbers in this assay, from the lowest: compounds 2, 3 and 1 (each within the scatter of the next).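

At the aromatic carbon para to a large group, the swap to cyano gives a 1.1-fold higher number from compound 2 to compound 3 (0.05 log units; within the scatter) and a 1.2-fold lower number from compound 1 to compound 3 (0.09 log units; within the scatter), both in this assay. The earlier compounds shown here showed only that one halogen could replace the other within the scatter; cyano, which enters with a triple bond and a hydrogen-bond acceptor, now also cannot be separated from either halogen on this read-out. No supporting data are available to explain this flat reading.

Going by these compounds, it remains open whether an amine, a carboxylic acid or a longer chain on this carbon would move the number beyond the scatter. Also open, on these data alone, is whether these three groups would still read alike if the shared core were changed elsewhere.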